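Dimethylamino for propylamino in a small series

The compounds below may be only part of what the source reports. "The series", "measured", "known", "first", "only" and "open" are said of these compounds alone.

In an ADME assay on a cell-free system (plasma, Homo sapiens) for protein binding, with Plasma (Rattus norvegicus) as the target, with a stated time of 1 h (a lower number here means a smaller unbound share, a higher number a larger unbound share of the compound), compound 1 (`Cn1c(C(C)(C)C)nc(C(=O)NCc2ccc(F)cc2C(N)=O)c(O)c1=O`) gives 0.06 of unbound drug, compound 2 (`CCNC(=O)c1cc(F)ccc1CNC(=O)c1nc(C(C)(C)C)n(C)c(=O)c1O`) gives 0.03 of unbound drug, and compound 3 (`CCCNC(=O)c1cc(F)ccc1CNC(=O)c1nc(C(C)(C)C)n(C)c(=O)c1O`) gives 0.02 of unbound drug. Compound 3 stands apart from compound 1 (a 3.0-fold lower number from compound 1 to compound 3 (0.48 log units; beyond the scatter)) but not from compound 2 (a 1.5-fold lower number from compound 2 to compound 3 (0.18 log units; within the scatter)). Compound 4 (`CN(C)C(=O)c1cc(F)ccc1CNC(=O)c1nc(C(C)(C)C)n(C)c(=O)c1O`) has dimethylamino in place of propylamino on a carbonyl carbon. For the measured compounds named here, no measured step removes the amide hydrogen from a substituted amide, so only the steps out of compound 1 offer a guide (a 2.0-fold lower number from compound 1 to compound 2 (0.30 log units; within the scatter); a 3.0-fold lower number from compound 1 to compound 3 (0.48 log units; beyond the scatter)). They are small, so only a small move in this assay is expected, towards a higher number (a 2.0-fold higher number from compound 3 to compound 4 (0.30 log units; within the scatter)). For compound 4 the estimated value is 0.04 (expected range 0.02 to 0.08).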

Compound 4, unbound fraction: 0.18
Beside the measured number, compound 4's estimate is 4.5-fold (0.65 log units) below it, outside the stated range (above it).
By their numbers in this assay, from the lowest: compounds 3, 2 and 1 (each within the scatter of the next, the first and the last beyond it); then compound 4.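

In this assay, dimethylamino on the carbonyl carbon reverses the direction set by the ethylamino and propylamino amides, with a 9.0-fold higher number from compound 3 to compound 4 (0.95 log units; beyond the scatter) and a 6.0-fold higher number from compound 2 to compound 4 (0.78 log units; beyond the scatter). It also goes past the plain amide, with a 3.0-fold higher number from compound 1 to compound 4 (0.48 log units; beyond the scatter), so compound 4 is the only one here without the amide hydrogen and holds the highest number of the four. Nothing measured here accounts for this rise. As far as these compounds go, whether the loss of the amide hydrogen or the pair of methyl groups matters remains open, and methylamino or diethylamino on the same carbonyl carbon could separate the two.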